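Oxadiazole in place of the oxetanyl carbamate on compound 2

The compounds below may be only part of what the source reports. "The series", "measured", "known", "first", "only" and "open" are said of these compounds alone.

Working notes on the series. Compound 1 `Cc1nc(S(C)(=O)=O)ccc1Oc1ncnc(OC2CCN(C(=O)O[C@H](C)C(F)(F)F)CC2)c1F` gives 9.2 nM in a functional assay on isolated protein for inhibition of Glucose-dependent insulinotropic receptor (Homo sapiens), read by HTRF and cAMP accumulation; a higher number here means that more compound is needed for the effect, a lower number that less compound is needed. Compound 2 `Cc1nc(S(C)(=O)=O)ccc1Oc1ncnc(OC2CCN(C(=O)OC3(C(F)(F)F)COC3)CC2)c1F` gives 29.3 nM in this assay, and compound 3 `Cc1nc(S(C)(=O)=O)ccc1Oc1ncnc(OC2CCN(C(=O)c3noc(C(C)(C)F)n3)CC2)c1F` gives 14 nM. Compound 2 carries the highest number of the three: the nearer gap is a 2.1-fold lower number from compound 2 to compound 3 (0.32 log units; beyond the scatter), the wider one is a 3.2-fold higher number from compound 1 to compound 2 (0.50 log units; beyond the scatter). Between compound 1 and compound 3 the step is a 1.5-fold higher number from compound 1 to compound 3 (0.18 log units; within the scatter).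

Compound 4 `Cc1nc(S(C)(=O)=O)ccc1Oc1ncnc(OC2CCN(C(=O)c3nc(C(C)(C)F)no3)CC2)c1F` differs from compound 2 by a group of 9 heavy atoms (5 carbon, 2 nitrogen, 1 oxygen, 1 fluorine; one five-membered aromatic ring with 3 hetero atoms) in place of a group of 9 heavy atoms (4 carbon, 2 oxygen, 3 fluorine; one four-membered non-aromatic ring with 1 hetero atom), on a carbonyl carbon. Among the compounds with values here, the counted change is the same as the one from compound 2 to compound 3; compound 3 and compound 4 differ only in how the ring is joined, and no step between them is available, so only their two values will tell. The step that bears directly is a 2.1-fold lower number from compound 2 to compound 3 (0.32 log units; beyond the scatter), a modest lowering beyond the scatter, while a 1.5-fold higher number from compound 1 to compound 3 (0.18 log units; within the scatter) shows the new group roughly matching compound 1. A modest lowering is therefore expected, a 2.0-fold lower number from compound 2 to compound 4 (0.29 log units; within the scatter). Because compound 3 gives 14 nM, compound 4 is estimated at 15 nM, expected within 6 nM to 40 nM.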

Compound 4, half-maximal effective concentration: 43.4 nM
Compound 4: middle estimate off by 2.9-fold (0.46 log units), on the low side, outside the stated range (above it).
By their numbers in this assay, from the lowest: compounds 1 and 3 (each within the scatter of the next); then compounds 2 and 4 (each within the scatter of the next).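

In this assay the connection of the five-membered ring to the carbonyl carbon matters at this position: the entering groups have the same counted atoms, yet the step is a 3.1-fold higher number from compound 3 to compound 4 (0.49 log units; beyond the scatter) and the lower number seen with the earlier ring does not carry over. Replacing (3-(trifluoromethyl)oxetan-3-yl)oxy with this ring gives a 1.5-fold higher number from compound 2 to compound 4 (0.17 log units; within the scatter) and so separates nothing, while the comparison with the 1-(trifluoromethyl)ethyl carbamate is a 4.7-fold higher number from compound 1 to compound 4 (0.67 log units; beyond the scatter) and shows that this ring no longer matches that carbamate as the earlier ring did. Nothing available accounts for the difference between the two ring connections.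

From the compounds shown here alone, it remains open whether that difference persists with a tert-butyl or cyclopropyl group on the ring in place of the fluorine-bearing group. A 1,3,4-oxadiazole at the same carbonyl carbon also remains untested among the compounds shown here.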